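Shortening the amide substituent in a butanoate thioether series

A few compounds are considered here, and "the series" means these few. Any claim that something is new, unique, unknown or untested is made for them only; others in the source may bear on it.

Compound 1 `CCCC(=O)OCSc1ccccc1C(=O)NCC(N)=O` — in an ADME assay on CEM-SS cells (Homo sapiens) for cytotoxicity, read by XTT assay, with a stated time of 6 days (on this read-out lower numbers stand for higher toxicity in this test and higher numbers for lower toxicity in this test), compound 1 gives a limit of the assay, > 100 uM.
Compound 2 `CCCC(=O)OCSc1ccccc1C(=O)NCCCCCNC(C)=O` — in this assay compound 2 gives 9.2 uM.
Compound 3 `CCCC(=O)OCSc1ccccc1C(=O)N[C@H]1CCC[C@H]1C(N)=O` — in this assay compound 3 gives 89.9 uM; 84.8 uM (2 entries).

Among the measured compounds shown here, compound 2 stands as the only single number in this assay; compound 3 contributes two entries, and compound 1 contributes only a limit. The change from compound 2 to compound 4 `CCCC(=O)OCSc1ccccc1C(=O)NC` is hydrogen in place of 4-acetamidobutyl on a saturated chain carbon bound to an amide-type nitrogen. For the measured compounds named here, the one measured step that bears on it is an at least 10-fold lower number from compound 1 to compound 2 (1.03 log units; beyond the scatter), where adding that chain lowered the number well beyond the scatter. Taking the chain away again is expected to reverse that step, moving compound 4 back toward the readings of compound 1 and compound 3. Compound 4 is therefore expected to give 60 uM, within 20 uM to 150 uM, an estimated step of a 6.5-fold higher number from compound 2 to compound 4 (0.81 log units; beyond the scatter).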

Compound 4, half-maximal toxic concentration: 5.7 uM
The estimate for compound 4 lay 11-fold (1.02 log units) above the measured number; the measured number lies below the stated range.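

Taking away the 4-acetamidobutyl chain did not bring the number back up: in this assay hydrogen in its place gives a 1.6-fold lower number from compound 2 to compound 4 (0.21 log units; within the scatter). Hydrogen in place of carbamoyl gives an at least 17-fold lower number from compound 1 to compound 4 (1.24 log units; beyond the scatter), so the low reading seen with the chain also appears without it. That step starts from a limit of the assay: the limit of > 100 uM in this assay, at which 1 of the 4 values shown sits.

The compounds shown leave open whether the high readings are tied to carbamoyl itself, or whether a carboxylic acid or an amine on this saturated chain carbon would read alike.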